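The source may report more compounds than this note shows. Statements on the series, on what has been measured and on what is new or still open speak of the compounds shown alone.

Compound 1 `CCC(=O)N(C)c1ccc2[nH]c(-c3n[nH]c4ccccc34)cc2n1` gives 6130 nM; compound 2 `CN(C(=O)C(C)(C)C)c1ccc2[nH]c(-c3n[nH]c4ccccc34)cc2n1` gives 4990 nM; compound 3 `COc1cccc(C(=O)N(C)c2ccc3[nH]c(-c4n[nH]c5ccccc45)cc3n2)c1` gives 1420 nM.

In a functional assay on HL-60 cells (Homo sapiens) for antiproliferative activity, read by MTT assay, with a stated time of 72 h (a lower number here means a stronger inhibitor, a higher number a weaker inhibitor), compound 3 stands lowest of the three numbers. The steps of a 4.3-fold lower number from compound 1 to compound 3 (0.64 log units; beyond the scatter) and a 3.5-fold lower number from compound 2 to compound 3 (0.55 log units; beyond the scatter) both lie beyond the scatter, whereas a 1.2-fold lower number from compound 1 to compound 2 (0.09 log units; within the scatter) stays within it. Compound 4 `CN(c1ccc2[nH]c(-c3n[nH]c4ccccc34)cc2n1)S(=O)(=O)c1ccc(Br)cc1` differs from compound 3 by (4-bromophenyl)sulfonyl in place of (3-methoxyphenyl)carbonyl on a nitrogen on an aromatic ring. The measured steps bear on this only in part: both show that an aromatic ring on the carbonyl carbon gave a lower number than an alkyl group, and compound 4 keeps an aromatic ring at this position. Going by the values given here, no measured step swaps the carbonyl for a sulfonyl, so the size of that change is unknown. The expected step is a 1.5-fold higher number from compound 3 to compound 4 (0.19 log units; within the scatter), with wide uncertainty. Compound 4 is therefore estimated at 2200 nM, in the range 600 nM to 8000 nM.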

Compound 4, half-maximal inhibitory concentration: 6240 nM
Compound 4: middle estimate off by 2.8-fold (0.45 log units), on the low side; low and high end bracket the measured number.
By their numbers in this assay, from the lowest: compound 3; then compounds 2, 1 and 4 (each within the scatter of the next).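

In this assay, an aromatic ring on this nitrogen's acyl-type group does not by itself keep the lower number: the switch to (4-bromophenyl)sulfonyl gives a clear loss (a 4.4-fold higher number from compound 3 to compound 4 (0.64 log units; beyond the scatter)). The sulfonyl compound instead falls level with the alkyl amides, with both a 1.3-fold higher number from compound 2 to compound 4 (0.10 log units; within the scatter) and a 1.0-fold higher number from compound 1 to compound 4 (0.01 log units; within the scatter) inside the scatter. No evidence is available that explains this result.

The sulfonyl and the ring substituent change together, so their shares in the loss stay unseparated. A 4-bromobenzoyl group or a (3-methoxyphenyl)sulfonyl group at this place would divide them.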